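The source may report more compounds than this note shows. Statements on the series, on what has been measured and on what is new or still open speak of the compounds shown alone.

Compound 1 `CCO/N=C/c1c(N)ncnc1Oc1ccc2[nH]c(C)cc2c1F` and compound 2 `COCCCO/N=C/c1c(N)ncnc1Oc1ccc2[nH]c(C)cc2c1F` share a core and differ in one place. In a functional assay on HCT-116 cells (Homo sapiens) for antiproliferative activity (a higher number here means a weaker inhibitor, a lower number a stronger inhibitor), compound 1 gives 36 nM, while compound 2 gives 438 nM, the highest of the two numbers measured; the step of a 12-fold higher number from compound 1 to compound 2 (1.09 log units; beyond the scatter) is the only one recorded, and it is large. Compound 3 `CNCCO/N=C/c1c(N)ncnc1Oc1ccc2[nH]c(C)cc2c1F` differs from compound 2 by methylamino in place of methoxymethyl on a saturated chain carbon, two bonds along the chain from an oxygen on an unsaturated carbon. Within the data shown here, the only bearing step is the one from compound 1 to compound 2, which shows that adding the methoxymethyl group raised the number well beyond the scatter; its removal in compound 3 is therefore expected to lower the number again, though the entering methylamino has no measured counterpart, so the estimate for compound 3 is placed between the two known values, as a 2.9-fold lower number from compound 2 to compound 3 (0.47 log units; beyond the scatter). Compound 3 is expected to give about 150 nM in this assay, within a range of 40 nM to 600 nM.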

Compound 3, half-maximal inhibitory concentration: 3010 nM
Estimate against measurement, compound 3: 20-fold (1.30 log units) below; measured number outside the range, above it.
By their numbers in this assay, from the lowest: compound 1; then compound 2; then compound 3.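

In this assay, methylamino does not bring the number back towards that of compound 1: the exchange for methoxymethyl gives a 6.9-fold higher number from compound 2 to compound 3 (0.84 log units; beyond the scatter) and, set against the hydrogen, the group gives an 84-fold higher number from compound 1 to compound 3 (1.92 log units; beyond the scatter) in this comparison. On a saturated chain carbon, two bonds along the chain from an oxygen on an unsaturated carbon, both groups shown thus raise the number, and methylamino raises it further than methoxymethyl does. Nothing at hand gives a reason for this order.

The step from 3-methoxypropoxy to 2-(methylamino)ethoxy changes the chain and its heteroatom together, so the compounds shown do not separate the two changes. Going by these compounds, it remains open whether a 3-(methylamino)propoxy chain would stand nearer compound 2, and how a hydroxyl, a dimethylamino group or a carboxylic acid would fare in this place.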